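Swapping the aryl group on the oxazole core of compound 2

This account rests on a few compounds, and the source may have more. Where it says the series, first, only, none or still open, it means among the compounds named here.

Compound 2 `Cc1oc(-c2ccc(Cl)cc2)nc1CN1CCC(C(=O)NCCCN2C[C@H](C)C[C@H](C)C2)CC1` sits in a series alongside compound 1 `CC[C@@H]1C[C@H](CC)CN(CCCNC(=O)C2CCN(Cc3nc(-c4ccccc4C)oc3C)CC2)C1` and compound 3 `Cc1cccc(Cl)c1-c1nc(CN2CCC(C(=O)NCCCN3CCC(C)(C)CC3)CC2)c(C)o1`. In an ADME assay on microsomes from liver (Rattus norvegicus) for metabolic stability, read by LC-MS, using NADPH, at 37 degrees C (on this read-out higher numbers stand for a longer-lived compound and lower numbers for a shorter-lived compound), compound 2 gives > 0.5 h, which is a limit of the assay rather than a number (the limit of > 0.5 h in this assay, at which 1 of the 3 values shown sits). Compound 1 gives 0.0917 h and compound 3 gives 0.0733 h in this assay. Compound 4 `Cc1cccc(C)c1-c1nc(CN2CCC(C(=O)NCCCN3C[C@H](C)C[C@H](C)C3)CC2)c(C)o1` is made from compound 2 by a single change: 2,6-dimethylphenyl in place of 4-chlorophenyl on an aromatic carbon. For the measured compounds named here, no measured pair isolates this change, so the direction rests on expectation alone. Compound 4 is expected to show a step of an at least 2.5-fold lower number from compound 2 to compound 4 (0.39 log units; beyond the scatter), a shortening beyond the scatter. Compound 4 is therefore estimated at 0.2 h, with a range from 0.06 h to 0.7 h in this assay.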

Compound 4, half-life: 0.0517 h
The estimate for compound 4 lay 3.9-fold (0.59 log units) above the measured number; the measured number lies below the stated range.
By their numbers in this assay, from the lowest: compounds 4, 3 and 1 (each within the scatter of the next). At a limit, above all of these: compound 2.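

In this assay, 2,6-dimethylphenyl in place of 4-chlorophenyl gives an at least 9.6-fold lower number from compound 2 to compound 4 (0.98 log units; beyond the scatter). For the compounds shown here, this shows that the aryl group at this position can by itself move the read-out beyond the scatter, which the earlier compounds, differing in more than one place, could not show. The size of the step remains a lower bound, as the value of compound 2 is a limit: the limit of > 0.5 h in this assay, at which 1 of the 4 values shown sits.

From the compounds shown here alone, whether an unsubstituted phenyl or a pyridyl group here would keep the longer half-life remains open. So does whether the step holds with a different amine at the end of the chain.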